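The source may report more compounds than this note shows. Statements on the series, on what has been measured and on what is new or still open speak of the compounds shown alone.

Measured so far in a functional assay on HeLa cells (Homo sapiens) for antiproliferative activity, read by MTT assay, with a stated time of 72 h; a lower number here means a stronger inhibitor, a higher number a weaker inhibitor:
- compound 1 `COc1ccc2occ(CSC(=S)N(C(C)C)C(C)C)c(=O)c2c1`: 5400 nM
- compound 2 `O=c1cc(CSC(=S)N2CCCC2)oc2ccccc12`: 23100 nM
- compound 3 `CC(C)N(C(=S)SCc1oc2ccccc2c(=O)c1Cl)C(C)C`: a limit, > 40000 nM

Compound 1 gives the lowest of the two numbers shown; the nearest is compound 2 at 23100 nM, a gap beyond the scatter, though the two structures differ in more than one place and no single step links them. Compound 3 sits at the limit of this assay and gives no number at all (the limit of > 40000 nM in this assay, at which 1 of the 3 values shown sits).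

The step to compound 4 `COc1ccc2occ(CSC(=S)N3CCCC3)c(=O)c2c1` is a single change on the shared core of compound 1: pyrrolidin-1-yl in place of diisopropylamino on a thiocarbonyl carbon. Going by the values given here, no pair of measured compounds shows this change on its own. Compound 2 carries the pyrrolidin-1-yl group but on a different core, so its value can only be noted, not counted as a step. For compound 4, a small move towards a higher number in this assay is expected, a 1.7-fold higher number from compound 1 to compound 4 (0.22 log units; within the scatter), of a size that may not exceed the scatter. The estimate for compound 4 in this assay is 9000 nM, with a range from 3000 nM to 30000 nM.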

Compound 4, half-maximal inhibitory concentration: 12100 nM
Compound 4: the middle estimate sits 1.3-fold (0.13 log units) below what was measured, and the stated range covers the measured number.
By their numbers in this assay, from the lowest: compound 1; then compounds 4 and 2 (each within the scatter of the next). At a limit, above all of these: compound 3.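

On the shared core of compound 1, the thiocarbonyl carbon now gives a first readable single-change result in this assay: pyrrolidin-1-yl in place of diisopropylamino gives a 2.2-fold higher number from compound 1 to compound 4 (0.35 log units; beyond the scatter), a modest step but one beyond the scatter. The step exchanges an open group of 7 heavy atoms for a five-membered non-aromatic ring of 5 heavy atoms, and this one pair does not separate the change in atom count from the presence of the ring. Nothing measured in the series bears on the reason for this step.

On these data alone, whether piperidin-1-yl, morpholin-4-yl or dimethylamino on the same thiocarbonyl carbon would separate these two features remains open. Also open, as far as these compounds go, is whether the same exchange gives a step of similar size on another core, since compound 2 and compound 3 each differ from compound 1 in more than one place and provide no direct comparison.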